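The source may report more compounds than this note shows. Statements on the series, on what has been measured and on what is new or still open speak of the compounds shown alone.

Measured in a functional assay on MCF7 cells (Homo sapiens) for antiproliferative activity, read by MTT assay; on this read-out higher numbers stand for weaker inhibition and lower numbers for stronger inhibition:
Compound 1 `COc1cc2c(Oc3ccc(NC(=O)Nc4cccc(C)c4)cc3)ccnc2cc1OCCCCCCC(=O)NO`: 1240 nM
Compound 2 `COc1cc2c(Oc3ccc(NC(=O)Nc4ccc(C)cc4C)cc3)ccnc2cc1OCCCCCCC(=O)NO`: 3430 nM
Compound 3 `COc1ccccc1NC(=O)Nc1ccc(Oc2ccnc3cc(OCCCCCCC(=O)NO)c(OC)cc23)cc1`: 6280 nM

The high end of these numbers belongs to compound 3. The steps leading there are a 5.1-fold higher number from compound 1 to compound 3 (0.70 log units; beyond the scatter) and a 1.8-fold higher number from compound 2 to compound 3 (0.26 log units; within the scatter).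

Compound 4 `COc1cc2c(Oc3ccc(NC(=O)N/N=C/c4ccccc4F)cc3)ccnc2cc1OCCCCCCC(=O)NO` keeps the shared core and brings (a group of 9 heavy atoms (7 carbon, 1 nitrogen, 1 fluorine; one six-membered aromatic ring of carbon only) in place of a group of 8 heavy atoms (7 carbon, 1 oxygen; one six-membered aromatic ring of carbon only), on an amide-type nitrogen). Among the measured compounds shown here, the entering group also has a double bond outside aromatic rings, which no measured compound offers at this place, so the nearest guide is other swaps on this amide-type nitrogen. Besides the two steps above, there is a 2.8-fold higher number from compound 1 to compound 2 (0.44 log units; beyond the scatter). These swaps are modest at most, so a modest step is expected here. Its direction is uncertain, with a slight lean towards a lower number since compound 3 sits at 6280 nM, the high end of the range. The expected change is a 1.8-fold lower number from compound 3 to compound 4 (0.25 log units; within the scatter). For compound 4 the estimated value is 3500 nM, with an expected range of 1000 nM to 12000 nM.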

Compound 4, half-maximal inhibitory concentration: 1610 nM
The estimate for compound 4 lay 2.2-fold (0.34 log units) above the measured number, within the range that was stated.
By their numbers in this assay, from the lowest: compounds 1 and 4 (each within the scatter of the next); then compounds 2 and 3 (each within the scatter of the next).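

In this assay, among the compounds shown here, this place on the amide-type nitrogen accepts a quite different group, one carrying a fluorine and a double bond outside aromatic rings, and the number drops clearly against two of the earlier compounds (a 3.9-fold lower number from compound 3 to compound 4 (0.59 log units; beyond the scatter); a 2.1-fold lower number from compound 2 to compound 4 (0.33 log units; beyond the scatter)). Against the third the step stays within the scatter (a 1.3-fold higher number from compound 1 to compound 4 (0.11 log units; within the scatter)), so the new group matches the best earlier result without passing it. Nothing available explains these shifts.

From the compounds shown here alone, this swap brings in the fluorine and the double bond together, so their separate shares stay unknown. Going by these compounds, whether a chlorine in place of the fluorine would hold the number remains open.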